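This account rests on a few compounds, and the source may have more. Where it says the series, first, only, none or still open, it means among the compounds named here.

Measured compounds in a functional assay on the whole organism (Tail, strain ICR) with Mus musculus as the target, in the tail flick test, with a stated time of 120 min, at a dose of 25 umol/kg by the oral route; a higher number here means a stronger effect of the compound at the dose given, a lower number a weaker effect:
- compound 1, `CC(C)[C@H](NC(=O)CN(c1ncnc2c1ncn2C1CCCCO1)C1CC1)C(=O)OCc1ccccc1`, gives 25.8%
- compound 2, `O=C(O)CC[C@H](NC(=O)CN(c1nc(Cl)nc2[nH]cnc12)C1CC1)C(=O)O`, gives 30.1%
- compound 3, `NC(=O)C[C@H](NC(=O)CN(c1nc(Cl)nc2[nH]cnc12)C1CC1)C(=O)O`, gives 17%

Among these three values compound 1 stands second highest. Its nearest neighbour is compound 2, which sits within the scatter of compound 1, and compound 3 lies furthest from it, also within the scatter, so no order can be claimed among the three.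

Compound 4, `O=C(CN(c1ncnc2c1ncn2C1CCCCO1)C1CC1)N[C@@H](CCC(=O)OCc1ccccc1)C(=O)OCc1ccccc1`, has not yet been measured in this assay. It differs from compound 1 in one place: 2-(benzyloxycarbonyl)ethyl in place of isopropyl on a saturated chain carbon bound to an amide-type nitrogen and a carbonyl carbon

Going by the values given here, only one measured step is known, a number 13.1 percentage points lower from compound 2 to compound 3 (beyond the scatter). That step changes the side chain on the same kind of chain carbon, but on a different core and with a different pair of groups, so it bears only loosely on the present change. Among the compounds with values here, the change from compound 1 to compound 4 brings in a larger side chain, and no measured pair shows what such a change does. The expected step in this assay is therefore small, a number 1.2 percentage points higher from compound 1 to compound 4 (within the scatter), within the scatter in either direction. Compound 4 is estimated at 27%, in the range 12% to 44%.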

Compound 4, a percentage reported as activity, at one dose (the size of the read-out at that dose, not a potency): 20.7%
Beside the measured number, compound 4's estimate is 6.3 percentage points above it; low and high end bracket the measured number.
By their numbers in this assay, from the lowest: compounds 3, 4, 1 and 2 (each within the scatter of the next, the first and the last beyond it).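

In this assay the position on the core of compound 1 now has its first measured step, a number 5.1 percentage points lower from compound 1 to compound 4 (within the scatter), for 2-(benzyloxycarbonyl)ethyl in place of isopropyl on the saturated chain carbon bound to an amide-type nitrogen and a carbonyl carbon. The entering group has 12 heavy atoms against 3, with a six-membered aromatic ring of carbon only and 2 hydrogen-bond acceptors, yet the step stays within the scatter, so this large change has no readable effect at this dose. Nothing at hand accounts for this result.

Going by these compounds, it remains open whether a carboxylic acid in place of the benzyloxycarbonyl group would give a step beyond the scatter on this core. The same holds for an amine or a longer chain at this position.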